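Amine ring size at the propoxy chain terminus

The compounds below may be only part of what the source reports. "The series", "measured", "known", "first", "only" and "open" are said of these compounds alone.

Measured compounds: compound 1 `COc1cc2c(Nc3nc4ccc(C(=O)Nc5c(C)cc(C)cc5C)cc4s3)ncnc2cc1OCCCN1CCC(C)CC1` 5600 nM; compound 2 `CCN(CC)CCCOc1cc2ncnc(Nc3nc4ccc(C(=O)Nc5c(C)cccc5Cl)cc4s3)c2cc1OC` 7300 nM; compound 3 `COc1cc2c(Nc3nc4ccc(C(=O)Nc5c(C)cccc5Cl)cc4s3)ncnc2cc1OCCCN1CCCC1` 19900 nM.

For the measured compounds named here, in a functional assay on U-937 cells (Homo sapiens) for cytotoxicity, read by WST assay, with a stated time of 72 h (on this read-out higher numbers stand for weaker inhibition and lower numbers for stronger inhibition), compound 3 gives the highest of the three numbers; compound 2 lies nearest, and the one step that touches this chain position, a 2.7-fold higher number from compound 2 to compound 3 (0.44 log units; beyond the scatter), is modest. Compound 4 `COc1cc2c(Nc3nc4ccc(C(=O)Nc5c(C)cccc5Cl)cc4s3)ncnc2cc1OCCCN1CCC(C)CC1` carries the change (4-methylpiperidin-1-yl in place of pyrrolidin-1-yl on a saturated chain carbon, three bonds along the chain from an oxygen on an aromatic ring). Going by the values given here, no measured step shows this exact exchange, but compound 1 carries the same 4-methylpiperidin-1-yl group on a different amide aryl and gives 5600 nM, below compound 3. On that basis compound 4 is expected to show a 2.5-fold lower number from compound 3 to compound 4 (0.40 log units; beyond the scatter), a moderate downward step. The estimate for compound 4 is therefore 8000 nM, within 3500 nM to 18000 nM.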

Compound 4, half-maximal inhibitory concentration: 9200 nM
Beside the measured number, compound 4's estimate is 1.2-fold (0.06 log units) below it; measured number inside the range.
By their numbers in this assay, from the lowest: compounds 1, 2 and 4 (each within the scatter of the next); then compound 3.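

In this assay, 4-methylpiperidin-1-yl in place of pyrrolidin-1-yl gives a 2.2-fold lower number from compound 3 to compound 4 (0.34 log units; beyond the scatter) as a direct exchange, whereas 4-methylpiperidin-1-yl in place of diethylamino gives only a 1.3-fold higher number from compound 2 to compound 4 (0.10 log units; within the scatter) and so does not separate these two amines. With 4-methylpiperidin-1-yl on the chain, 2-chloro-6-methylphenyl in place of 2,4,6-trimethylphenyl on the amide nitrogen gives a 1.6-fold higher number from compound 1 to compound 4 (0.22 log units; within the scatter) and likewise does not separate the two. No evidence bears on why the pyrrolidin-1-yl compound differs. The compounds shown leave open whether an unsubstituted piperidine, a morpholine or a piperazine at the chain end would group with compound 3 or compound 4. They also leave open how a shorter chain would read.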